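This account rests on a few compounds, and the source may have more. Where it says the series, first, only, none or still open, it means among the compounds named here.

Measured in an ADME assay on microsomes from liver (Homo sapiens) for metabolic stability; a lower number here means that the compound disappears faster, a higher number that the compound lasts longer:
- Compound 1 `CC(C)C(c1ncco1)c1ccc(-c2ccc3cccc(F)c3c2)[nH]c1=O`: 0.178 h
- Compound 2 `CC(C)C(c1ccc(-c2ccc3cccc(F)c3c2)[nH]c1=O)N1CCNC1=O`: 1.03 h

Of these two compounds, compound 2 has the higher number, 1.03 h, so it lasts longer in this assay. The next structure, compound 3 `CC(C)C(CC(N)=O)c1ccc(-c2ccc3cccc(F)c3c2)[nH]c1=O`, changes the group at the same place: carbamoylmethyl in place of 2-oxoimidazolidin-1-yl on a saturated chain carbon bound to an aromatic carbon and a saturated chain carbon. Carbamoylmethyl replaces 2-oxoimidazolidin-1-yl on a saturated chain carbon bound to an aromatic carbon and a saturated chain carbon.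

Going by the values given here, only one measured step bears on this change. It is a 5.8-fold higher number from compound 1 to compound 2 (0.76 log units; beyond the scatter), and it lies beyond the scatter. That step shows that a swap at this place can move the half-life, but it involves a different pair of groups and cannot give the direction for compound 3. The leaving and entering groups match in their hydrogen-bond donor and acceptor counts, though the ring is lost. No step beyond the scatter is therefore expected, with a slight lean towards a lower number. The estimated step is a 1.5-fold lower number from compound 2 to compound 3 (0.17 log units; within the scatter). For compound 3 the estimated half-life is 0.7 h, with an expected range from 0.25 h to 2 h.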

Compound 3, half-life: < 0.0667 h
Compound 3 ended at the assay's limit (the forecaster's own chance of this, stated with the estimate: 3%); middle value at least 10-fold (1.02 log units) from the limit.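

In this assay, compound 3 gives no exact half-life, only a limit of the assay: the limit of < 0.0667 h in this assay, at which 1 of the 3 values shown sits.

Even so, the change at this saturated chain carbon is clear: replacing 2-oxoimidazolidin-1-yl with carbamoylmethyl gives an at least 15-fold lower number from compound 2 to compound 3 (1.18 log units; beyond the scatter), although both groups have the same hydrogen-bond donor and acceptor counts, so matching those counts did not keep the half-life in these two compounds. Carbamoylmethyl also compares poorly with the aromatic 1,3-oxazol-2-yl group, giving an at least 2.6-fold lower number from compound 1 to compound 3 (0.42 log units; beyond the scatter), which places it last of the three groups shown and makes 2-oxoimidazolidin-1-yl first.

As far as these compounds go, the exact size of both steps remains open, as does the question of which difference between compound 2 and compound 3 matters: the lost ring, the smaller group, or the carbon rather than ring nitrogen attached at this position. An open-chain urea would keep the attached nitrogen without the ring, while a longer chain ending in the same primary amide, or a carboxylic acid in its place, would show how much depends on the chain and on the amide itself.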